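The source may report more compounds than this note shows. Statements on the series, on what has been measured and on what is new or still open speak of the compounds shown alone.

Measured in a functional assay on ECa-109 cells for inhibition, with ECa-109 cell line (Homo sapiens) as the target, read by sulforhodamine B assay; a lower number here means a stronger inhibitor, a higher number a weaker inhibitor:
- compound 1 `O=C1C=C(Nc2ccccc2F)C(=O)c2c1nc1n2[C@H]2OC[C@@H](O)[C@H]2OC1`: 2760 nM
- compound 2 `COc1ccc(NC2=CC(=O)c3nc4n(c3C2=O)[C@H]2OC[C@@H](O)[C@H]2OC4)cc1`: > 4000 nM
- compound 3 `O=C1C=C(Nc2ccccc2)C(=O)c2c1nc1n2[C@H]2OC[C@@H](O)[C@H]2OC1`: 4970 nM

The entry for compound 2, > 4000 nM, is a limit and not a number. In this assay, going by the values given here, compound 3 gives 4970 nM, and the only other number comes from compound 1, at 2760 nM. These two lie within the scatter of each other.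

Compound 4 `O=C1C=C(Nc2cccc(Cl)c2)C(=O)c2c1nc1n2[C@H]2OC[C@@H](O)[C@H]2OC1` has chloro in place of hydrogen on an aromatic carbon, meta to a large group, so phenyl becomes 3-chlorophenyl: chloro in place of hydrogen on an aromatic carbon.

The closest measured change is hydrogen in place of fluoro on an aromatic carbon: a 1.8-fold higher number from compound 1 to compound 3 (0.26 log units; within the scatter). Replacing the 2-fluorophenyl group with 4-methoxyphenyl gives an at least 1.4-fold higher number from compound 1 to compound 2 (0.16 log units; that floor lies within the scatter), which rests on a limit. Among the compounds with values here, neither step shows a change beyond the scatter, and no chloro compound has been measured, so no clear step is expected in this assay. The estimated step is a 1.5-fold lower number from compound 3 to compound 4 (0.18 log units; within the scatter). For compound 4 the expected value is 3300 nM. The estimated range for compound 4 runs from 1500 nM to 7000 nM.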

Compound 4, half-maximal inhibitory concentration: 4690 nM
The estimate for compound 4 lay 1.4-fold (0.15 log units) below the measured number; the measured number falls inside the stated range.
By their numbers in this assay, from the lowest: compounds 1, 4 and 3 (each within the scatter of the next).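

Going by these compounds alone, compound 4 gives the first reading for a group at this position, as the earlier compounds carried only hydrogen there. In this assay, chloro in place of hydrogen on an aromatic carbon, meta to a large group, gives a 1.1-fold lower number from compound 3 to compound 4 (0.03 log units; within the scatter), and moving from 2-fluorophenyl to 3-chlorophenyl on the amine nitrogen gives a 1.7-fold higher number from compound 1 to compound 4 (0.23 log units; within the scatter). Compound 2 is recorded only as a limit, and its step to compound 4 cannot be read: the limit of > 4000 nM in this assay, at which 1 of the 4 values shown sits.

As far as these compounds go, whether an amine or a carboxylic acid at this position would give a step beyond the scatter remains open. Also open, from the compounds shown here alone, is whether any change to the shared core, rather than to the anilino group, would do so.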